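A few compounds are considered here, and "the series" means these few. Any claim that something is new, unique, unknown or untested is made for them only; others in the source may bear on it.

In a functional assay on U-251 cells (Homo sapiens) (a lower number here means a stronger inhibitor of growth, a higher number a weaker inhibitor of growth), three compounds sharing one core have been measured. Compound 1 `N#Cc1ccc(/C=C/S(=O)(=O)Cc2ccc(Nc3ncnc4ccccc34)cc2)cc1` gives > 100000 nM, which is a limit of the assay and not a number. Compound 2 `O=S(=O)(/C=C/c1ccc(F)cc1F)Cc1ccc(Nc2ncnc3ccccc23)cc1` gives > 100000 nM, which is also a limit. Going by the values given here, compound 3 `O=S(=O)(/C=C/c1ccc(C(F)(F)F)cc1F)Cc1ccc(Nc2ncnc3ccccc23)cc1` gives 100000 nM, the only true number in the set, while the other two compounds sit at the limit of > 100000 nM in this assay, at which 2 of the 3 values shown sit. Compound 4 `O=S(=O)(/C=C/c1ccc(C(F)(F)F)cc1F)Cc1ccc(Nc2ncnc3ccc(Br)cc23)cc1` differs from compound 3 in one place: bromo in place of hydrogen on an aromatic carbon. The measured steps bear on this only indirectly: a step that the two limits leave unreadable from compound 1 to compound 2, a number no higher from compound 1 to compound 3 (the limit leaves the size open) and a number no higher from compound 2 to compound 3 (the limit leaves the size open). None of them has a readable size, and none involves bromo, so any forecast is loose. Compound 3 at 100000 nM shows no growth inhibition of any strength so far, so a modest move to a lower number is the cautious expectation. The expected step is a 2.5-fold lower number from compound 3 to compound 4 (0.40 log units; beyond the scatter). For compound 4 the estimated value is 40000 nM, with an expected range from 5000 nM to 100000 nM.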

Compound 4, concentration for 50% growth inhibition: 30000 nM
The estimate for compound 4 lay 1.3-fold (0.12 log units) above the measured number, within the range that was stated.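

In this assay, bromo in place of hydrogen on an aromatic carbon of the fused system of two rings gives a 3.3-fold lower number from compound 3 to compound 4 (0.52 log units; beyond the scatter). Going by these compounds alone, this is the first readable change in the set, and it shows that a bromo at this position can lower the number, although compound 4 still needs 30000 nM to reach half growth inhibition. The earlier steps all changed the aromatic group on the double-bonded chain carbon, and they cannot be read because limits hide their size: the limit of > 100000 nM in this assay, at which 2 of the 4 values shown sit.

From the compounds shown here alone, whether this step is specific to bromo stays open, since a chloro, a methoxy or an amine on the same carbon would be needed to tell. Going by these compounds, it is also open whether bromo would lower the number in the same way with the 4-cyanophenyl of compound 1 or the 2,4-difluorophenyl of compound 2.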